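Methoxy for fluoro on the fused ring of compound 1

The compounds below may be only part of what the source reports. "The series", "measured", "known", "first", "only" and "open" are said of these compounds alone.

Compound 1 `COc1ccc(-c2ccc(C)n2-c2ccc(-c3nc4ccc(F)cc4s3)cc2)cc1` gives 3070 nM in a functional assay on MDA-MB-231 cells (Homo sapiens) for cytotoxicity, read by sulforhodamine B assay, with a stated time of 48 h (a higher number here means a weaker inhibitor of growth, a lower number a stronger inhibitor of growth), the higher of the two numbers measured; compound 2 `Cc1ccc(-c2ccc([N+](=O)[O-])cc2)n1-c1ccc(-c2nc3ccc(F)cc3s2)cc1` gives 1670 nM, a difference of a 1.8-fold lower number from compound 1 to compound 2 (0.26 log units; within the scatter). Compound 3 `COc1ccc(-c2ccc(C)n2-c2ccc(-c3nc4ccc(OC)cc4s3)cc2)cc1` differs from compound 1 by methoxy in place of fluoro on an aromatic carbon. Among the compounds with values here, no measured step touches this position; the only step known, from compound 1 to compound 2, changes a different ring and stays within the scatter. No step beyond the scatter is therefore expected from compound 1 to compound 3, an estimated 1.0-fold lower number from compound 1 to compound 3 (0.01 log units; within the scatter). For compound 3 the expected value is 3000 nM, in the range 1200 nM to 8000 nM.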

Compound 3, concentration for 50% growth inhibition: 4120 nM
For compound 3 the middle estimate is 1.4-fold (0.14 log units) below the measured one, within the range that was stated.
By their numbers in this assay, from the lowest: compounds 2, 1 and 3 (each within the scatter of the next, the first and the last beyond it).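

In this assay, within the data shown here, methoxy in place of fluoro on the fused ring gives a 1.3-fold higher number from compound 1 to compound 3 (0.13 log units; within the scatter), the first measured step at this position. This read-out therefore does not separate these two groups here, on the core of compound 1. No measurement shown gives a reason for this result.

As far as these compounds go, whether an amine or a carboxylic acid at this position would give a step beyond the scatter stays open. So does whether the same exchange would give a similar step on compound 2, which carries nitro instead of the methoxy that compound 1 has on its other ring.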